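A few compounds are considered here, and "the series" means these few. Any claim that something is new, unique, unknown or untested is made for them only; others in the source may bear on it.

In a functional assay on COLO 320 cells (Homo sapiens) for cytotoxicity, read by MTT assay, with a stated time of 4 h (a lower number here means a stronger inhibitor, a higher number a weaker inhibitor), compound 1 (`COC(=O)C1=CO[C@@H](O[C@@H]2O[C@H](COC(c3ccccc3)(c3ccccc3)c3ccccc3)[C@@H](O)[C@H](O)[C@H]2O)[C@@H]2[C@@H](C)[C@@H](O)C[C@H]12`) gives 0.25 ug/mL, and compound 2 (`COC(=O)C1=CO[C@@H](O[C@@H]2O[C@H](COC(c3ccccc3)(c3ccccc3)c3ccccc3)[C@@H](OC(=O)O)[C@H](OC(C)=O)[C@H]2OC(C)=O)[C@@H]2[C@@H](C)[C@@H](OC(C)=O)C[C@H]12`) gives 0.82 ug/mL. Compound 3 (`COC(=O)C1=CO[C@@H](O[C@@H]2O[C@H](CO)[C@@H](OC(C)=O)[C@H](OC(C)=O)[C@H]2OC(C)=O)[C@@H]2[C@@H](C)[C@@H](OC(C)=O)C[C@H]12`) has no number at all: it is reported as "not active" (no number reported), so it offers no fixed starting point. Compound 4 (`C=CC(=O)OC[C@H]1O[C@@H](O[C@@H]2OC=C(C(=O)OC)[C@H]3C[C@H](OC(C)=O)[C@H](C)[C@@H]23)[C@H](OC(C)=O)[C@@H](OC(C)=O)[C@@H]1OC(C)=O`) has not yet been measured. The change is vinylcarbonyl in place of hydrogen on an oxygen on a saturated carbon, so hydroxymethyl becomes ((vinylcarbonyl)oxy)methyl. For the measured compounds named here, no measured step shows what this change does, so the size of the step in this assay cannot be fixed. The expected direction is a modest move towards stronger inhibition, to a weak but measurable value, though a result of not active remains quite possible. For compound 4 the expected value is 5 ug/mL, with an estimated range of 1 ug/mL to 25 ug/mL.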

Compound 4, half-maximal inhibitory concentration: "not active" (no number reported)
Compound 4 has no reported number here; no gap can be computed for the estimate.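

In this assay compound 3 and compound 4 are both reported as not active, without a number, so no step can be read between them. The compounds shown leave open whether changing hydroxymethyl to ((vinylcarbonyl)oxy)methyl has any effect on potency. No data shown bear on this result.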